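The source may hold more compounds than are shown below. What is called first, only, known or untested is meant among the compounds shown, and "the series" means these compounds.

Of the compounds shown here, two built on a shared core have been measured so far. Compound 1 `O=C1/C(=C\c2ccc(F)cc2)c2ccccc2N1c1c(Cl)cccc1Cl` gives 13 ug/mL in a functional assay on L132 cells (Homo sapiens) for cytotoxicity, read by MTT assay, with a stated time of 72 h (on this read-out lower numbers stand for an effect already at smaller amounts and higher numbers for an effect only at larger amounts of compound), the lower of the two numbers; compound 2 `Cc1ccc2nc(Cl)c(/C=C3\C(=O)N(c4c(Cl)cccc4Cl)c4ccccc43)cc2c1C` gives 98 ug/mL in this assay, a higher number that lies beyond the scatter. Compound 3 `O=C1/C(=C\c2ccc(Cl)cc2)c2ccccc2N1c1c(Cl)cccc1Cl` differs from compound 1 by chloro in place of fluoro on an aromatic carbon. Within the data shown here, no measured pair shows this change, so the expectation rests on compound 1 alone. This step is expected to be small, within the scatter: a 1.1-fold lower number from compound 1 to compound 3 (0.03 log units; within the scatter). Compound 3 is estimated at 12 ug/mL, with a range from 6 ug/mL to 26 ug/mL.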

Compound 3, concentration for half-maximal effect: 9 ug/mL
Compound 3: the middle estimate sits 1.3-fold (0.12 log units) above what was measured; low and high end bracket the measured number.
By their numbers in this assay, from the lowest: compounds 3 and 1 (each within the scatter of the next); then compound 2.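

In this assay, 4-fluorophenyl and 4-chlorophenyl give numbers that cannot be told apart (a 1.4-fold lower number from compound 1 to compound 3 (0.16 log units; within the scatter)). This first measured pair therefore shows that, at this aromatic carbon, chloro in place of fluoro leaves the read-out within the scatter. Nothing available explains this closeness.

Still open, going by these compounds, is whether a group of another kind at the same place, such as an amine, a methoxy group or a carboxylic acid, would give a number beyond the scatter.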